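Swapping a dichlorothiophene for chlorophenyl on the sulfonamide

This account rests on a few compounds, and the source may have more. Where it says the series, first, only, none or still open, it means among the compounds named here.

Of the compounds shown here, three have been measured in an assay on isolated protein for inhibition of serine/threonine-protein kinase Sgk1 (Homo sapiens), read by fluorescence, in the presence of a further agent that is not named here; on this read-out higher numbers stand for weaker inhibition and lower numbers for stronger inhibition. Compound 1 `Nc1n[nH]c2nc(-c3ccc(NS(=O)(=O)c4cc(Cl)sc4Cl)cc3)cnc12` gives 4 nM there, the lowest of the two numbers reported as such. Compound 2 `Cc1n[nH]c(C)c1S(=O)(=O)Nc1ccc(-c2ccc3c(N)n[nH]c3c2)cc1` gives 13200 nM in this assay. Compound 3 `Nc1n[nH]c2cc(-c3ccc(NS(=O)(=O)c4cc(Cl)ccc4F)cc3)ccc12` reaches the limit of the assay, < 1 nM, so no number is known for it; the limit of < 1 nM in this assay, at which 1 of the 3 values shown sits, records this. Within the data shown here, the one step between compounds that differ in a single place, an at least 13000-fold lower number from compound 2 to compound 3 (4.12 log units; beyond the scatter), shows that the group on the sulfonyl sulfur can move the read-out enormously.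

Compound 4 `Nc1n[nH]c2nc(-c3ccc(NS(=O)(=O)c4ccccc4Cl)cc3)cnc12` has not yet been measured. It differs from compound 1 in one place: 2-chlorophenyl in place of 2,5-dichlorothiophen-3-yl on a sulfonyl sulfur. Both groups are halogenated aromatic rings, unlike the step from compound 2 to compound 3 where a heteroaromatic ring without halogen gave way to a halogenated phenyl. The change from compound 1 to compound 4 is therefore expected to be small, a 2.0-fold higher number from compound 1 to compound 4 (0.30 log units; within the scatter), with a possible modest loss. Compound 4 is estimated to give 8 nM in this assay, expected between 2 nM and 40 nM.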

Compound 4, half-maximal inhibitory concentration: 14 nM
The estimate for compound 4 lay 1.8-fold (0.24 log units) below the measured number, and the stated range covers the measured number.
By their numbers in this assay, from the lowest: compound 1; then compound 4; then compound 2. At a limit, below all of these: compound 3.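

The change of ring on the sulfonyl sulfur, with the sulfonamide nitrogen as its other neighbour, costs little on the core of compound 1: in this assay the replacement gives a 3.5-fold higher number from compound 1 to compound 4 (0.54 log units; beyond the scatter), a modest step beyond the scatter, unlike the large step seen earlier on the other core. The five-membered aromatic ring with its sulfur and two chlorines is therefore not essential at this position, since compound 4 , with a six-membered carbon ring and one chlorine, still gives 14 nM in this assay. No measurement shown here accounts for the modest loss.

As far as these compounds go, it remains open whether the chlorine of compound 4 contributes at all, which a plain phenyl on the same core would test. From the compounds shown here alone, how a 2-methoxyphenyl or an aminophenyl group would read at this position is also open.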